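Moving the amino group of compound 2 on its ring

A few compounds are considered here, and "the series" means these few. Any claim that something is new, unique, unknown or untested is made for them only; others in the source may bear on it.

Values measured in a functional assay on the whole organism (arterial blood) with Rattus norvegicus as the target (a lower number here means that less compound is needed, a higher number that more compound is needed for the effect), are these
compound 1 `Cc1nc2cnccc2n1CC1CCN(C(=O)/C=C/c2ccc(N)cc2)CC1` gives 1.23 mg/kg
compound 2 `Cc1nc2cnccc2n1CC1CCN(C(=O)/C=C(/c2ccccc2)c2ccc(N)cc2)CC1` gives 0.029 mg/kg
compound 3 `Cc1nc2cnccc2n1CC1CCN(C(=O)/C=C(\c2ccccc2)c2ccc(N)cc2)CC1` gives 0.01 mg/kg

Compound 2 holds the middle place among the three numbers, with compound 3 lower and compound 1 higher. Compound 4 `Cc1nc2cnccc2n1CC1CCN(C(=O)/C=C(/c2ccccc2)c2cccc(N)c2)CC1` has not yet been measured and has the same atoms as compound 2 joined differently. The change is 3-aminophenyl in place of 4-aminophenyl on a double-bonded chain carbon bound to an aromatic carbon and a double-bonded chain carbon and nothing else differs. The closest measured step is a 2.9-fold lower number from compound 2 to compound 3 (0.46 log units; beyond the scatter) and the only known difference behind it is the fact that compounds 2 and 3 differ only in the configuration as drawn (a change of configuration, not of the amino group). Among the compounds with values here, no measured step moves the amino group on its ring, so this step serves only as a guide to size. A modest step is therefore expected in this assay with a slight lean towards a higher number, which the data do not firmly support. The estimated step is a 2.1-fold higher number from compound 2 to compound 4 (0.32 log units; beyond the scatter) and its direction remains uncertain. Compound 4 is expected at 0.06 mg/kg (estimated range 0.015 mg/kg to 0.25 mg/kg).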

Compound 4, dose for 50% inhibition: 0.015 mg/kg
Compound 4: the middle estimate sits 4.0-fold (0.60 log units) above what was measured; the measured number falls inside the stated range.
By their numbers in this assay, from the lowest: compounds 3, 4 and 2 (each within the scatter of the next, the first and the last beyond it); then compound 1.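

Replacing 4-aminophenyl with 3-aminophenyl on the double-bonded chain carbon gives a 1.9-fold lower number from compound 2 to compound 4 (0.29 log units; within the scatter) in this assay, so this first measured move of the amino group on its ring produces no separable difference. The earlier compounds had shown that configuration alone can shift the number beyond the scatter, as in a 2.9-fold lower number from compound 2 to compound 3 (0.46 log units; beyond the scatter), whereas these two placings of the amino group cannot be told apart. Nothing at hand bears on why the two placings read alike.

The compounds shown leave open how 3-aminophenyl would read in the double-bond configuration of compound 3. They also leave open whether the amine itself matters, since a hydroxyl, a methoxy group or an acetamide on the same ring could read differently.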